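Swapping the Aryl Group on Compound 3

The source may hold more compounds than are shown below. What is called first, only, known or untested is meant among the compounds shown, and "the series" means these compounds.

In a functional assay on HepG2 cells (Homo sapiens) for cytotoxicity, read by MTT assay, with a stated time of 72 h (on this read-out lower numbers stand for stronger inhibition and higher numbers for weaker inhibition), compound 2 `CNC(=O)c1cc(Oc2ccc(C3=NNC(c4cccc([N+](=O)[O-])c4)C3)cc2)ccn1` gives 26500 nM. Compound 3 `CNC(=O)c1cc(Oc2ccc(C3=NN(C(N)=S)C(c4cccc([N+](=O)[O-])c4)C3)cc2)ccn1` returns only a limit of the assay, > 50000 nM. Compound 1 `CNC(=O)c1cc(Oc2ccc(C3=NNC(c4ccc(Cl)cc4Cl)C3)cc2)ccn1` offers no comparison, and its entry reads "not determined" (no result reported). For the measured compounds named here, compound 3 therefore has no exact number, and the only numerical value in this small set belongs to compound 2.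

Compound 4 `CNC(=O)c1cc(Oc2ccc(C3=NN(C(N)=S)C(c4ccc(Cl)cc4)C3)cc2)ccn1` keeps the core and the side group of compound 3 and changes one substituent: 4-chlorophenyl in place of 3-nitrophenyl on a saturated ring carbon. In words, 4-chlorophenyl stands in place of 3-nitrophenyl on a saturated ring carbon.

Going by the values given here, only one measured step is available, an at least 1.8-fold higher number from compound 2 to compound 3 (0.27 log units; that floor lies within the scatter). It lies within the scatter and concerns a different place in the structure, so it says nothing directly about this exchange of aryl groups. The evidence on that step ends at the limit of > 50000 nM in this assay, at which 1 of the 3 values shown sits. Among the compounds with values here, no measured pair isolates the new substituent, so no step beyond the scatter is expected in this assay. The expected size is an at least 1.4-fold lower number from compound 3 to compound 4 (0.15 log units; that floor lies within the scatter), an estimate that leans only slightly toward a lower number. Another report of a limit would fit this expectation equally well.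

For compound 4 the estimated value is 35000 nM, with an expected range from 10000 nM to 80000 nM.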

Compound 4, half-maximal inhibitory concentration: > 50000 nM
Compound 4: only a limit was reported; the forecaster's own chance of this, stated with the estimate: 45%; at least 1.4-fold (0.15 log units) between middle value and limit.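

In this assay compound 4 gives > 50000 nM, which is a limit of the assay. Compound 3 stands at a limit as well, so no step can be read between compound 3 and compound 4. The compounds shown leave open whether 4-chlorophenyl in place of 3-nitrophenyl on a saturated ring carbon changes the read-out in this assay at all.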